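Anilino-to-benzylamino swap on the shared quinone core

The compounds below may be only part of what the source reports. "The series", "measured", "known", "first", "only" and "open" are said of these compounds alone.

Compound 1 `O=C1C(Nc2ccc(I)cc2)=CC(=O)c2c1nc1n2[C@H]2OC[C@@H](O)[C@H]2OC1` is the reference point of the series. In a functional assay on ECa-109 cells for inhibition, with ECa-109 cell line (Homo sapiens) as the target, read by sulforhodamine B assay (on this read-out lower numbers stand for stronger inhibition and higher numbers for weaker inhibition), compound 1 gives 2530 nM, the lowest of the two numbers in hand. Compound 2 `O=C1C=C(Nc2cccc(F)c2)C(=O)c2c1nc1n2[C@H]2OC[C@@H](O)[C@H]2OC1` carries 3-fluorophenyl on the amine nitrogen and in this assay compound 2 gives 7030 nM, a gap from compound 1 that lies beyond the scatter. Compound 3 `COc1ccccc1NC1=CC(=O)c2nc3n(c2C1=O)[C@H]1OC[C@@H](O)[C@H]1OC3` carries 2-methoxyphenyl on the amine nitrogen; in this assay compound 3 gives > 4000 nM, which is a limit of the assay and not a number. Going by the values given here, the only measured single change, a step that the limit leaves unreadable from compound 2 to compound 3, is therefore unreadable in size due to the limit of > 4000 nM in this assay, at which 1 of the 3 values shown sits.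

Compound 4 `O=C1C(NCc2ccccc2)=CC(=O)c2c1nc1n2[C@H]2OC[C@@H](O)[C@H]2OC1` departs from compound 1 by benzyl in place of 4-iodophenyl on an amine nitrogen. Among the compounds with values here, no measured step covers a move from an aryl to a benzyl group on the amine nitrogen, so the expectation rests on compound 1 alone, with wide uncertainty; the unreadable step from compound 2 to compound 3 hints only that this nitrogen substituent matters. For compound 4 the expected value in this assay is 5000 nM, between 1500 nM and 15000 nM, an expected step of a 2.0-fold higher number from compound 1 to compound 4 (0.30 log units; within the scatter).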

Compound 4, half-maximal inhibitory concentration: > 8000 nM
Compound 4 was reported as a limit; the forecaster's own chance of this, stated with the estimate: 35%; at least 1.6-fold (0.20 log units) between middle value and limit.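

In this assay, the amine nitrogen now has a readable step, and moving from 4-iodophenyl to benzyl gives an at least 3.1-fold higher number from compound 1 to compound 4 (0.49 log units; beyond the scatter). The two groups match in the counts of heavy atoms and aromatic rings, so this step shows that the assay distinguishes between two substituents of equal count on this nitrogen. Compound 4 stands as a limit of the assay, so the step has a lower bound and no exact size: the limit of > 8000 nM in this assay, at which 1 of the 4 values shown sits.

The change removes the iodine and adds a carbon link on the nitrogen together, so the compounds shown do not tell which of the two goes with the weaker reading, and 4-iodobenzyl on the amine nitrogen would separate them. The step from compound 2 to compound 3 still cannot be read, which leaves the effect of other aryl groups on this nitrogen open.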